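The source may report more compounds than this note shows. Statements on the series, on what has been measured and on what is new or still open speak of the compounds shown alone.

- Compound 1 (`O=C(/C=C1\CCc2ccccc21)NC1CC1`) measures 71 mg/kg
- Compound 2 (`NC(=O)/C=C1/CCc2ccccc21`) measures 44 mg/kg

Going by the values given here, in a functional assay on the whole organism with Mus musculus as the target (a higher number here means that more compound is needed for the effect, a lower number that less compound is needed), compound 1 stands within the usual scatter of compound 2, the only other measured compound, so neither can be ranked above the other. Compound 3 (`NC(=O)/C=C1\CCc2ccccc21`) has not yet been measured. It differs from compound 1 by hydrogen in place of cyclopropyl on an amide-type nitrogen. Among the compounds with values here, no measured pair shows this change, so no step beyond the scatter is expected in this assay, and no firm direction can be given. The estimated step is a 1.4-fold lower number from compound 1 to compound 3 (0.15 log units; within the scatter) and would remain within the scatter. For compound 3, the expected value is 50 mg/kg, with an estimated range from 20 mg/kg to 120 mg/kg.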

Compound 3, dose for half-maximal effect: 31 mg/kg
Beside the measured number, compound 3's estimate is 1.6-fold (0.21 log units) above it; low and high end bracket the measured number.
By their numbers in this assay, from the lowest: compounds 3, 2 and 1 (each within the scatter of the next, the first and the last beyond it).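

In this assay, going by these compounds alone, replacing cyclopropyl with hydrogen on the amide-type nitrogen gives the first step beyond the scatter (a 2.3-fold lower number from compound 1 to compound 3 (0.36 log units; beyond the scatter)). At this position, less compound is needed with hydrogen than with cyclopropyl, although the step is modest. Reversing the double bond gives a step within the scatter (a 1.4-fold lower number from compound 2 to compound 3 (0.15 log units; within the scatter)), so this pair shows no clear effect of the drawn geometry, and it is a clean comparison: the fact that compounds 2 and 3 differ only in the configuration as drawn.

As far as these compounds go, whether a methyl or a longer chain on this nitrogen would match hydrogen or cyclopropyl remains open. So does whether the cyclopropyl step holds with the double bond drawn the other way.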